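The compounds below may be only part of what the source reports. "The series", "measured", "known", "first", "only" and "open" are said of these compounds alone.

Working notes on the series. Compound 1 `C#CC(C)OC(=O)c1ccc(C(CC)(CC)c2ccc(OCCC(O)(CC)CC)c(C)c2)n1CC` carries a (1-methylprop-2-yn-1-yl)oxy group on the carbonyl carbon. In a functional assay on Caco-2 cells (Homo sapiens) for antiproliferative activity, read by MTT assay, with a stated time of 48 h (a lower number here means a stronger inhibitor, a higher number a weaker inhibitor), compound 1 returns only a limit, > 50000 nM. Compound 2 `CCC(C)C(CO)NC(=O)c1ccc(C(CC)(CC)c2ccc(OCCC(O)(CC)CC)c(C)c2)n1CC` likewise returns only a limit in this assay, > 50000 nM. Among the measured compounds shown here, compound 3 `CCn1c(C(=O)N(C)CCO)ccc1C(CC)(CC)c1ccc(OCCC(O)(CC)CC)c(C)c1` is the single compound with a readable number in this assay, 74 nM. Accordingly a step that the two limits leave unreadable from compound 1 to compound 2 cannot be sized, whereas an at least 670-fold lower number from compound 1 to compound 3 (2.82 log units; beyond the scatter) and an at least 670-fold lower number from compound 2 to compound 3 (2.82 log units; beyond the scatter) are both large, and compound 1 stands no better than the limit of > 50000 nM in this assay, at which 2 of the 3 values shown sit.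

Compound 4 `CCn1c(C(=O)NC(C)CO)ccc1C(CC)(CC)c1ccc(OCCC(O)(CC)CC)c(C)c1` is the next case: (1-(hydroxymethyl)ethyl)amino in place of (1-methylprop-2-yn-1-yl)oxy on a carbonyl carbon. The entering group resembles that of compound 2 more closely than the (2-hydroxyethyl)(methyl)amino group of compound 3, so the evidence bearing on the step is mixed: one neighbour sits at the limit, the other is potent. For compound 4 a weak to moderate result is expected, estimated at 8000 nM within 500 nM to 50000 nM. This expectation corresponds to an estimated step of an at least 6.2-fold lower number from compound 1 to compound 4 (0.79 log units; beyond the scatter), with a real chance that only a limit is reported again.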

Compound 4, half-maximal inhibitory concentration: > 50000 nM
Compound 4: only a limit was reported (the forecaster's own chance of this, stated with the estimate: 40%); middle value at least 6.2-fold (0.79 log units) from the limit.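

In this assay, a hydroxyl-bearing amino group on the carbonyl carbon is not enough to keep a readable number, since moving from (2-hydroxyethyl)(methyl)amino to (1-(hydroxymethyl)ethyl)amino gives an at least 670-fold higher number from compound 3 to compound 4 (2.82 log units; beyond the scatter). The steps from compound 1 and from compound 2 to compound 4 cannot be read, as both ends of each are limits, so methyl in place of sec-butyl on the saturated chain carbon shows no readable gain. Among the compounds shown, compound 3 is the only one to come off the shared limit: the limit of > 50000 nM in this assay, at which 3 of the 4 values shown sit.

The change from compound 3 to compound 4 alters the substitution on the amino nitrogen and the hydroxyl-bearing chain together, so the compounds shown do not separate the two. On these data alone, the (2-hydroxyethyl)amino and (1-(hydroxymethyl)ethyl)(methyl)amino groups would bear on that question, and how either would read here remains open.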